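Urea series: second chloro on the aryl urea

The source may report more compounds than this note shows. Statements on the series, on what has been measured and on what is new or still open speak of the compounds shown alone.

Two members of the series have numbers in a functional assay on NCI-H460 cells (Homo sapiens) for cytotoxicity, read by MTT assay, with a stated time of 72 h; a lower number here means a stronger inhibitor, a higher number a weaker inhibitor. Compound 1 `CN(C)CCCNc1nc(-c2ccc(NC(=O)Nc3ccc(Cl)cc3Cl)cc2)nc2c(Cl)c(Cl)sc12` gives 980 nM. Compound 2 `CCN(CC)CCNc1nc(-c2ccc(NC(=O)Nc3ccccc3Cl)cc2)nc2c(Cl)c(Cl)sc12` gives 460 nM, the lowest of the two numbers; compound 1 sits higher by a gap that is beyond the usual scatter. Compound 1 and compound 2 differ in two places at once, in the amine chain and in the chloro pattern of the aryl urea, so the gap between them cannot be assigned to either change on its own.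

Compound 3 `CCN(CC)CCNc1nc(-c2ccc(NC(=O)Nc3ccc(Cl)cc3Cl)cc2)nc2c(Cl)c(Cl)sc12` has not yet been measured in this assay. It keeps the amine chain of compound 2 and carries the aryl urea of compound 1: chloro in place of hydrogen on an aromatic carbon, on an aromatic carbon of a six-membered aromatic ring of carbon only, meta to a chloro group and para to a large group.

Going by the values given here, with no single-change step available, the step from compound 2 to compound 3 is expected to be small, at most a modest move toward the number of compound 1, possibly none beyond the scatter; the expected step is a 1.4-fold higher number from compound 2 to compound 3 (0.15 log units; within the scatter). Compound 3 is therefore estimated at 650 nM, within a range from 300 nM to 1400 nM.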

Compound 3, half-maximal inhibitory concentration: 1300 nM
Compound 3: middle estimate off by 2.0-fold (0.30 log units), on the low side; the measured number falls inside the stated range.
By their numbers in this assay, from the lowest: compound 2; then compounds 1 and 3 (each within the scatter of the next).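

In this assay, going by these compounds alone, adding chloro to the 2-chlorophenyl urea at the place para to the large group, giving 2,4-dichlorophenyl, produces a 2.8-fold higher number from compound 2 to compound 3 (0.45 log units; beyond the scatter), the first single-change reading at this position, and the change runs against activity on this chain. With the 2,4-dichlorophenyl urea held constant, diethylamino in place of (dimethylamino)methyl on the chain gives a 1.3-fold higher number from compound 1 to compound 3 (0.12 log units; within the scatter), so of the two differences between compound 1 and compound 2, only the chloro step lies beyond the scatter. No measurement shown here accounts for the chloro step.

The chloro effect rests on one pair, and whether it carries over to the amine chain of compound 1 remains open, as that chain is shown only with the 2,4-dichlorophenyl urea. Also open, on these data alone, is whether a fluoro, methyl or methoxy group at the same place would give a step like that of chloro, which would indicate whether the step is specific to chloro or extends to substitution there in general.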